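Naphthyl for Methoxyphenyl on the Pyrazoline Carbon

The source may hold more compounds than are shown below. What is called first, only, known or untested is meant among the compounds shown, and "the series" means these compounds.

Measured compounds:
compound 1 `COc1ccc(C2CC(c3ccc4ccccc4c3)=NN2C2=NC(=O)/C(=C3\C(=O)Nc4ccccc43)S2)cc1` — 12400 nM
compound 2 `O=C1N=C(N2N=C(c3ccccc3)CC2c2ccc(Cl)cc2)S/C1=C1/C(=O)Nc2ccccc21` — 390 nM
compound 3 `COc1ccc(C2=NN(C3=NC(=O)/C(=C4\C(=O)Nc5ccccc54)S3)C(c3ccc(Cl)cc3)C2)cc1` — 100000 nM

Of the compounds shown here, three sharing one core have been tested in a functional assay on cells (Cancer cell lines, Homo sapiens) for cytotoxicity, read by sulforhodamine B assay, with a stated time of 48 h; a lower number here means a stronger inhibitor of growth, a higher number a weaker inhibitor of growth. Compound 2 `O=C1N=C(N2N=C(c3ccccc3)CC2c2ccc(Cl)cc2)S/C1=C1/C(=O)Nc2ccccc21` gives 390 nM; compound 1 `COc1ccc(C2CC(c3ccc4ccccc4c3)=NN2C2=NC(=O)/C(=C3\C(=O)Nc4ccccc43)S2)cc1` gives 12400 nM; compound 3 `COc1ccc(C2=NN(C3=NC(=O)/C(=C4\C(=O)Nc5ccccc54)S3)C(c3ccc(Cl)cc3)C2)cc1` gives 100000 nM, the highest of the three numbers, far from compound 2 and well beyond the scatter from compound 1.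

Going by the values given here, the one single-point step among them is a 260-fold higher number from compound 2 to compound 3 (2.41 log units; beyond the scatter), so the methoxy group alone accounts for a large loss.

Compound 4 `O=C1N=C(N2N=C(c3ccc4ccccc4c3)CC2c2ccc(Cl)cc2)S/C1=C1/C(=O)Nc2ccccc21` differs from compound 3 by naphthalen-2-yl in place of 4-methoxyphenyl on a carbon with a double bond to nitrogen. Among the compounds with values here, this both removes the methoxy group that hurt compound 3 and enlarges the ring system; no measured step isolates the second part. Compound 1 carries the same naphthalen-2-yl group with a different group elsewhere and sits between compounds 2 and 3.

Compound 4 is therefore expected to fall well below compound 3, by about a 67-fold lower number from compound 3 to compound 4 (1.82 log units; beyond the scatter), landing near 1500 nM with a range of 200 nM to 12000 nM.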

Compound 4, concentration for total growth inhibition: 70300 nM
Compound 4: middle estimate off by 47-fold (1.67 log units), on the low side; measured number outside the range, above it.
By their numbers in this assay, from the lowest: compound 2; then compound 1; then compounds 4 and 3 (each within the scatter of the next).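

In this assay, the change at this carbon gives a 1.4-fold lower number from compound 3 to compound 4 (0.15 log units; within the scatter), so replacing 4-methoxyphenyl with naphthalen-2-yl does not recover the low number of compound 2. Both changes from phenyl fall on the same high side, since a 260-fold higher number from compound 2 to compound 3 (2.41 log units; beyond the scatter) is matched by a 180-fold higher number from compound 2 to compound 4 (2.26 log units; beyond the scatter), and among these three compounds only phenyl at this carbon carries the low number. The substituent on the other aromatic ring still counts with naphthalen-2-yl in place, as a 5.7-fold higher number from compound 1 to compound 4 (0.75 log units; beyond the scatter) shows that chloro in place of methoxy goes with a higher number here, so the two places do not act alike across these compounds.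

Nothing shown explains these differences. As far as these compounds go, it also stays open how an amine, a carboxylic acid or a short alkyl chain at this carbon would compare with phenyl.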